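Swapping Fluoro for Chloro in an Oral Writhing-Test Series

The source may report more compounds than this note shows. Statements on the series, on what has been measured and on what is new or still open speak of the compounds shown alone.

Three compounds were measured in a functional assay on the whole organism for inhibition, with Mus musculus as the target, in the writhing test, with a stated time of 1 h, at a dose of 60 mg/kg by the oral route; on this read-out higher numbers stand for more inhibition at the one dose given (going by the name of the read-out) and lower numbers for less inhibition:
Compound 1 `COc1ccc(C2C(C)C(=O)CC(c3ccc(Cl)cc3)N2C(=O)CN2CCN(C)CC2)cc1` gives 53.1%.
Compound 2 `CC1C(=O)CC(c2ccc(F)cc2)N(C(=O)CCl)C1c1ccc(O)cc1` gives 51.2%.
Compound 3 `COc1ccc(C2C(C)C(=O)CC(c3ccc(F)cc3)N2C(=O)CCl)cc1` gives 51.2%.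

Compound 3 stands level with compound 2, the two together at the bottom of the three, and compound 1 sits within the scatter of both. Among the compounds with values here, the only measured step, no change at the digits printed from compound 2 to compound 3 (within the scatter), shows that methyl in place of hydrogen on an oxygen on an aromatic ring left the read-out unchanged. Compound 4 `COc1ccc(C2C(C)C(=O)CC(c3ccc(Cl)cc3)N2C(=O)CCl)cc1` differs from compound 3 by chloro in place of fluoro on an aromatic carbon. Within the data shown here, no measured step covers this change; compound 1, which also carries chloro, gives a value within the scatter of compound 3. The step expected here, a number 0.8 percentage points higher from compound 3 to compound 4 (within the scatter), stays within the scatter. Compound 4 is estimated at 52%, between 40% and 63%.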

Compound 4, a percentage reported as inhibition, in the whole organism at one dose (the size of the read-out at that dose, not a potency): 44.1%
Estimate against measurement, compound 4: 7.9 percentage points above; the range from low to high includes it.
By their numbers in this assay, from the lowest: compounds 4, 2, 3 and 1 (each within the scatter of the next).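

Going from 4-fluorophenyl to 4-chlorophenyl gives the first direct reading of this change in this assay, namely a number 7.1 percentage points lower from compound 3 to compound 4 (within the scatter), so this assay does not separate the two halogens at this aromatic carbon. Chloro in place of 4-methylpiperazin-1-yl on the saturated chain carbon gives a number 9 percentage points lower from compound 1 to compound 4 (within the scatter), so the two groups at that carbon are not separated either. No evidence on the cause of these numbers is available.

The compounds shown leave open whether a bromo or a nitrile on that aromatic carbon would stand apart from fluoro and chloro. They also leave open how a morpholine on the chain carbon would read.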